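From compound 2 to compound 3: an expected rise

The source may report more compounds than this note shows. Statements on the series, on what has been measured and on what is new or still open speak of the compounds shown alone.

Compound 1 `c1cc([C@H]2CC[C@]3(CC2)OOC2(O3)C3CC4CC(C3)CC2C4)ccc1OCCOC1CCNCC1` gives 50 ug/mL in a physicochemical assay for solubility, read by nephelometry, measured as kinetic solubility, with a stated time of 30 min; a lower number here means a less soluble compound, a higher number a more soluble compound
Compound 2 `CC(C)(O)CN1CCC(Oc2ccc([C@H]3CC[C@]4(CC3)OOC3(O4)C4CC5CC(C4)CC3C5)cc2)CC1` gives 1.6 ug/mL in this assay

Among the measured compounds shown here, compound 2 holds the lower of the two numbers, and the one measured step, a 31-fold lower number from compound 1 to compound 2 (1.49 log units; beyond the scatter), is large and lies beyond the scatter. The move to compound 3 `c1cc([C@H]2CC[C@]3(CC2)OOC2(O3)C3CC4CC(C3)CC2C4)ccc1OCCC1CCNCC1` is 2-(piperidin-4-yl)ethyl in place of 1-(2-hydroxy-2-methylpropyl)piperidin-4-yl on an oxygen on an aromatic ring, so that 2-(piperidin-4-yl)ethyl stands in place of 1-(2-hydroxy-2-methylpropyl)piperidin-4-yl on an oxygen on an aromatic ring. The measured step bears directly on this change. The group leaving compound 2 is the one that replaced 2-((piperidin-4-yl)oxy)ethyl in the step from compound 1, and the entering group differs from that earlier name only in its chain. For the measured compounds named here, no measured pair shows what that remaining difference does, so some caution is due. A large rise in this assay is therefore expected, a little smaller than the measured step in size, and a 16-fold higher number from compound 2 to compound 3 (1.19 log units; beyond the scatter) is the estimated step. Compound 3 is estimated at 25 ug/mL, with 7 ug/mL as the expected lower end and 70 ug/mL as the expected upper end.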

Compound 3, solubility: > 100 ug/mL
Compound 3: only a limit was reported; the forecaster's own chance of this, stated with the estimate: 5%; at least 4.0-fold (0.60 log units) between middle value and limit.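

On an oxygen on an aromatic ring, 2-(piperidin-4-yl)ethyl in place of 1-(2-hydroxy-2-methylpropyl)piperidin-4-yl gives an at least 62-fold higher number from compound 2 to compound 3 (1.79 log units; beyond the scatter) in this assay, which shows that this position can carry a change of large size in the upward direction as well as the downward one. Compound 3 carries a limit of the assay and not a number, the first such result in this series: the limit of > 100 ug/mL in this assay, at which 1 of the 3 values shown sits.

Among the compounds shown here, the pair with the closest chain also appears for the first time, with piperidin-4-yl in place of (piperidin-4-yl)oxy on a saturated chain carbon, two bonds along the chain from an oxygen on an aromatic ring, and it reads as an at least 2.0-fold higher number from compound 1 to compound 3 (0.30 log units; that floor lies within the scatter), so no order can be claimed from it.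

On these data alone, the true value of compound 3 stays open, and with it the full size of both steps. Also open, as far as these compounds go, is what 2-(piperidin-4-yl)ethyl would give with a 2-hydroxy-2-methylpropyl group added to its ring, and what a longer chain or a carboxylic acid on the same oxygen would give.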